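Sulfonyl aryl swap on a shared quinoline-free core, compound 4

The compounds below may be only part of what the source reports. "The series", "measured", "known", "first", "only" and "open" are said of these compounds alone.

Measured so far:
compound 1 `Cc1ccc(S(=O)(=O)c2cnc3ccc(F)cc3c2N2CCC(C)CC2)cc1F`: 86%
compound 2 `CC1CCN(c2c(S(=O)(=O)c3ccccc3)cnc3ccc(F)cc23)CC1`: 40%
compound 3 `Cc1ccc(S(=O)(=O)c2cnc3ccc(F)cc3c2N2CCC(C)CC2)cc1Cl`: 91%

In an assay on isolated protein for displacement of a labelled ligand from metabotropic glutamate receptor 5 (Homo sapiens), with a stated time of 60 min, tested at 1 uM (on this read-out higher numbers stand for more inhibition at the one concentration tested (going by the name of the read-out) and lower numbers for less inhibition), compound 3 gives the largest of the three figures, although the step of a number 5 percentage points higher from compound 1 to compound 3 (within the scatter) is within the scatter, so compound 1 and compound 3 cannot be ranked; only compound 2 stands apart, by a number 51 percentage points higher from compound 2 to compound 3 (beyond the scatter). Compound 4 `COc1cccc(S(=O)(=O)c2cnc3ccc(F)cc3c2N2CCC(C)CC2)c1` differs from compound 3 in one place: 3-methoxyphenyl in place of 3-chloro-4-methylphenyl on a sulfonyl sulfur. For the measured compounds named here, the steps that bear on this are those in which the aryl on the sulfonyl sulfur changed: a number 46 percentage points lower from compound 1 to compound 2 (beyond the scatter) and a number 51 percentage points higher from compound 2 to compound 3 (beyond the scatter), both large and both linking a bare phenyl to a substituted one. Compound 4 keeps a substituted phenyl, so a moderate fall in this assay is expected, a number 29 percentage points lower from compound 3 to compound 4 (beyond the scatter). Compound 4 is estimated at 62%, between 35% and 85%.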

Compound 4, a percentage reported as inhibition, at one concentration (the size of the read-out at that concentration, not a potency): 90%
The estimate for compound 4 lay 28 percentage points below the measured number; the measured number lies above the stated range.
By their numbers in this assay, from the lowest: compound 2; then compounds 1, 4 and 3 (each within the scatter of the next).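

In this assay, the 3-methoxyphenyl on the sulfonyl sulfur cannot be told apart from either aryl carrying a methyl and a halogen: a number 1 percentage points lower from compound 3 to compound 4 (within the scatter) and a number 4 percentage points higher from compound 1 to compound 4 (within the scatter). Against the bare phenyl there is a number 50 percentage points higher from compound 2 to compound 4 (beyond the scatter), so a single methoxy, with no chloro, fluoro or methyl on the ring, suffices for the large step from phenyl. Nothing available explains this result. Still open, going by these compounds, is whether an amine or a carboxylic acid in place of that methoxy would give a similar figure.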